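A few compounds are considered here, and "the series" means these few. Any claim that something is new, unique, unknown or untested is made for them only; others in the source may bear on it.

Three compounds built on the same core differ only in the alkyl group on one of the two ester oxygens. Compound 1 `CCOC(=O)C1=C(C)NC(C)=C(C(=O)OCC)C1c1csc(-c2ccc(Cl)cc2)n1` carries an ethyl group there; in an assay on isolated protein for antagonist activity at Voltage-dependent L-type calcium channel subunit alpha-1C (Cavia porcellus), with a stated time of 15 min (on this read-out lower numbers stand for stronger inhibition and higher numbers for weaker inhibition), compound 1 gives 3650 nM. Compound 2 `CCOC(=O)C1=C(C)NC(C)=C(C(=O)OC(C)C)C1c1csc(-c2ccc(Cl)cc2)n1` carries an isopropyl group, and in this assay compound 2 gives 2550 nM; the step of a 1.4-fold lower number from compound 1 to compound 2 (0.16 log units; within the scatter) lies within the scatter. Compound 3 `CCOC(=O)C1=C(C)NC(C)=C(C(=O)OC(C)(C)C)C1c1csc(-c2ccc(Cl)cc2)n1` carries a tert-butyl group, and in this assay compound 3 gives 91000 nM, the highest of the three numbers and so the weakest inhibitor, since the steps of a 25-fold higher number from compound 1 to compound 3 (1.40 log units; beyond the scatter) and a 36-fold higher number from compound 2 to compound 3 (1.55 log units; beyond the scatter) are both large and beyond the scatter.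

Compound 4 `CCOC(=O)C1=C(C)NC(C)=C(C(=O)OC2CCCCC2)C1c1csc(-c2ccc(Cl)cc2)n1` differs from compound 3 by cyclohexyl in place of tert-butyl on an oxygen next to a carbonyl group. Within the data shown here, the steps that bear on this change are a 25-fold higher number from compound 1 to compound 3 (1.40 log units; beyond the scatter) and a 36-fold higher number from compound 2 to compound 3 (1.55 log units; beyond the scatter), which show how sharply the number rose when tert-butyl entered, while a 1.4-fold lower number from compound 1 to compound 2 (0.16 log units; within the scatter) shows that the earlier growth of the ester group changed little. Cyclohexyl is larger than tert-butyl but is a ring rather than a triply branched chain, so the expectation is that much, though perhaps not all, of the loss is recovered: compound 4 is expected to give a lower number, with the step of a 15-fold lower number from compound 3 to compound 4 (1.18 log units; beyond the scatter). The estimate for compound 4 in this assay is 6000 nM, with a range from 1500 nM to 40000 nM.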

Compound 4, half-maximal inhibitory concentration: 100000 nM
Compound 4: the middle estimate sits 17-fold (1.22 log units) below what was measured, outside the stated range (above it).
By their numbers in this assay, from the lowest: compounds 2 and 1 (each within the scatter of the next); then compounds 3 and 4 (each within the scatter of the next).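

In this assay, cyclohexyl in place of tert-butyl on an oxygen next to a carbonyl group leaves the number unchanged within the scatter (a 1.1-fold higher number from compound 3 to compound 4 (0.04 log units; within the scatter)), so the ring does not bring back what was lost when tert-butyl entered. The gaps to the ethyl and isopropyl esters stay large (a 27-fold higher number from compound 1 to compound 4 (1.44 log units; beyond the scatter); a 39-fold higher number from compound 2 to compound 4 (1.59 log units; beyond the scatter)), which places ethyl and isopropyl together and tert-butyl and cyclohexyl together, and shows that the high number at this position is not peculiar to tert-butyl, as a group with a ring and a group without one share it. No measurement shown here explains why these four groups sort this way.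

The compounds shown leave open where between isopropyl and these two groups the number climbs, which a cyclopropyl, cyclobutyl or cyclopentyl ester, or a straight butyl or hexyl chain, could help to locate. They also leave open whether an ester group carrying an amine or a phenyl ring at this position would give a number nearer that of compound 1 or that of compound 4.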